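Removing One Chloro Group from a Purine-Like Core

A few compounds are considered here, and "the series" means these few. Any claim that something is new, unique, unknown or untested is made for them only; others in the source may bear on it.

Compound 1 `ClCc1ccccc1Cn1cnc2c(Cl)nc(Cl)nc21` carries two chloro groups on its core and a substituted benzyl group on a ring nitrogen. In a functional assay on HOP-92 cells (Homo sapiens) for cytotoxicity, read by sulforhodamine B assay, with a stated time of 48 h (a lower number here means a stronger inhibitor of growth, a higher number a weaker inhibitor of growth), compound 1 gives 350 nM. Compound 2 `ClCc1ccccc1Cn1cnc2c(Cl)ncnc21` differs from compound 1 only by hydrogen in place of chloro on an aromatic carbon; in this assay compound 2 gives 1480 nM. The step is a 4.2-fold higher number from compound 1 to compound 2 (0.63 log units; beyond the scatter), so losing this chloro group weakens growth inhibition to a modest but real degree.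

Compound 3 `ClCc1ccc(Cn2cnc3nc(Cl)nc(Cl)c32)cc1` is built from the same atoms as compound 1, joined differently; the difference between the two cores is not broken down here. As far as these compounds go, for compound 3 this assay gives "not determined" (no result reported), so its value is unknown.

Compound 4 `ClCc1ccc(Cn2cnc3ncnc(Cl)c32)cc1` is to compound 3 what compound 2 is to compound 1: it differs by hydrogen in place of chloro on an aromatic carbon. The place of the change matches the earlier one word for word, so the same kind of change is made.

For the measured compounds named here, with no number for compound 3, an expectation for compound 4 can rest only on the one measured pair. If the core of compound 3 behaves like that of compound 1, then the step from compound 3 to compound 4 is expected to resemble the one from compound 1 to compound 2, namely a 4.2-fold higher number from compound 1 to compound 2 (0.63 log units; beyond the scatter), and compound 4 is expected to land near compound 2. On that basis compound 4 is estimated at 1500 nM in this assay, with a wide band from 300 nM to 8000 nM that reflects the missing anchor.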

Compound 4, concentration for 50% growth inhibition: 1170 nM
Compound 4: the middle estimate sits 1.3-fold (0.11 log units) above what was measured; the range from low to high includes it.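

For the compounds shown here, compound 3 has no reported value, so although compound 4 gives 1170 nM in this assay, no step from compound 3 to compound 4 can be read. The compounds shown leave open whether swapping chloro for hydrogen on the core of compound 3 changes growth inhibition as it does on the core of compound 1. Nothing available here offers an explanation for the value of compound 4.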